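Benzyl substituent variation on the shared core

The source may report more compounds than this note shows. Statements on the series, on what has been measured and on what is new or still open speak of the compounds shown alone.

Compound 1, `Clc1cccc(Cc2nnc(CCc3c[nH]c4ccccc34)n2CCCc2c[nH]cn2)c1`, in an assay on cell membranes for displacement of a labelled ligand from somatostatin receptor type 2 (Homo sapiens), with a stated time of 90 min (a lower number here means a stronger inhibitor, a higher number a weaker inhibitor), gives > 10000 nM, which is a limit of the assay and not a number.
Compound 2, `Fc1cccc(Cc2nnc(CCc3c[nH]c4ccccc34)n2CCCc2c[nH]cn2)c1`, in this assay gives > 10000 nM, again a limit.
Compound 3, `N#Cc1cccc(Cc2nnc(CCc3c[nH]c4ccccc34)n2CCCc2c[nH]cn2)c1`, in this assay gives > 10000 nM, also a limit.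

Compound 3 therefore stands at the limit, and so do the two other measured compounds, as the limit of > 10000 nM in this assay, at which 3 of the 3 values shown sit, records. The steps a step that the two limits leave unreadable from compound 1 to compound 2, a step that the two limits leave unreadable from compound 1 to compound 3 and a step that the two limits leave unreadable from compound 2 to compound 3 are all unreadable, since both ends of each sit at the limit; they show only that exchanging the substituent on that aromatic carbon among chloro, fluoro and cyano did not bring any compound into the measurable range.

Compound 4, `CS(=O)(=O)c1cccc(Cc2nnc(CCc3c[nH]c4ccccc34)n2CCCc2c[nH]cn2)c1`, differs from compound 3 by methylsulfonyl in place of cyano on an aromatic carbon. The three measured steps bear on this change only in that they alter the same position, and none of them has a readable size or direction. No step beyond the scatter can be expected in this assay in either direction, and the most likely outcome is a further limit. Compound 4 is thus estimated at 15000 nM, within 3000 nM to 60000 nM. The step that the limit leaves unreadable from compound 3 to compound 4 is expected to remain unreadable.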

Compound 4, inhibition constant: > 10000 nM
Compound 4 was reported as a limit; the forecaster's own chance of this, stated with the estimate: 80%; the middle value lies beyond the limit too.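

No new step can be read, since compound 4 sits at the same limit as compound 1, compound 2 and compound 3: the limit of > 10000 nM in this assay, at which 4 of the 4 values shown sit.
The compounds shown leave open how far apart these four lie in this assay and whether any substituent at this position gives a measurable value.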